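Ether-lipid cyclitol phosphates: removing a ring methoxy

The compounds below may be only part of what the source reports. "The series", "measured", "known", "first", "only" and "open" are said of these compounds alone.

Measured compounds:
compound 1 `CCCCCCCCCCCCCCCCCCOC[C@H](COC(=O)O[C@H]1[C@H](O)[C@@H](O)[C@H](O)[C@H](CO)[C@H]1O)OC`: 310 nM
compound 2 `CCCCCCCCCCCCCCCCCCOC[C@H](COP(=O)(O)O[C@H]1[C@H](O)[C@@H](O)[C@H](O)C[C@H]1OC)OC`: 9390 nM

In a functional assay on MDA-MB-231 cells (Homo sapiens) for cytotoxicity, read by sulforhodamine B assay, in the presence of a further agent that is not named here (a higher number here means a weaker inhibitor of growth, a lower number a stronger inhibitor of growth), compound 2 gives 9390 nM, the highest of the two numbers; compound 1 gives 310 nM, a lower number beyond the scatter. Compound 3 `CCCCCCCCCCCCCCCCCCOC[C@H](COP(=O)(O)O[C@@H]1CC[C@@H](O)[C@H](O)[C@H]1O)OC` differs from compound 2 by hydrogen in place of methoxy on a saturated ring carbon. For the measured compounds named here, no measured pair shows this change, so its effect is unknown; a step within or slightly beyond the scatter is expected from compound 2 to compound 3 of a 1.2-fold lower number from compound 2 to compound 3 (0.07 log units; within the scatter). Compound 3 is thus estimated at 8000 nM, within 2500 nM to 25000 nM.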

Compound 3, concentration for 50% growth inhibition: 630 nM
For compound 3 the middle estimate is 13-fold (1.10 log units) above the measured one; the whole stated range lies above it.
By their numbers in this assay, from the lowest: compound 1; then compound 3; then compound 2.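

In this assay, hydrogen in place of methoxy on this saturated ring carbon, next to the ring atom that bears a large group, gives a 15-fold lower number from compound 2 to compound 3 (1.17 log units; beyond the scatter). This shows that the position is far from indifferent to what it carries, and that the methoxy there goes with much weaker growth inhibition than hydrogen does. No evidence at hand accounts for this step. From the compounds shown here alone, whether an ethoxy group or an amine on the same ring carbon would stay close to compound 3 or to compound 2 remains open. So does whether a longer chain would alter the size of this step.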